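Working notes: from compound 3 to compound 4

The source may hold more compounds than are shown below. What is called first, only, known or untested is meant among the compounds shown, and "the series" means these compounds.

Measured in an ADME assay on BHK cells (Mesocricetus auratus) for cytotoxicity, read by MTT assay, with a stated time of 96 h; a higher number here means that more compound is tolerated, a lower number that less compound is tolerated (half-maximal cytotoxic concentration):
- compound 1 `FC(F)(F)c1cccc(NC(=S)Nc2ccc(I)cc2)c1` gives 9400 nM
- compound 2 `CC(=O)NC(=S)Nc1cccc(C(F)(F)F)c1` gives > 100000 nM (a limit of the assay)
- compound 3 `FC(F)(F)c1cccc(NC(=S)Nc2cccc(Br)c2)c1` gives 10000 nM

Compound 3 has one numerical neighbour, and the step of a 1.1-fold higher number from compound 1 to compound 3 (0.03 log units; within the scatter) stays within the scatter. Going by the values given here, the only other reading is the limit held by compound 2 (the limit of > 100000 nM in this assay, at which 1 of the 3 values shown sits).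

Compound 4 `CSCCCNC(=S)Nc1cccc(C(F)(F)F)c1` carries 3-(methylsulfanyl)propyl in place of 3-bromophenyl on an amide-type nitrogen. Exchanging one aromatic group for another gave a 1.1-fold higher number from compound 1 to compound 3 (0.03 log units; within the scatter) and so no real change. Compound 2, with acetyl at that nitrogen, behaves differently: the measured steps are an at least 10-fold higher number from compound 1 to compound 2 (1.02 log units; beyond the scatter) and an at least 10-fold lower number from compound 2 to compound 3 (1.00 log units; beyond the scatter) in return. Compound 4 also has no ring in that group, so a higher number is expected in this assay, though the shift is expected to be smaller than those around compound 2. The estimated change is a 3.0-fold higher number from compound 3 to compound 4 (0.48 log units; beyond the scatter) in that direction. Compound 4 is estimated at 30000 nM (expected range 10000 nM to 90000 nM).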

Compound 4, half-maximal cytotoxic concentration: > 100000 nM
Compound 4 gave a limit, no number (the forecaster's own chance of this, stated with the estimate: 15%); at least 3.3-fold (0.52 log units) between middle value and limit.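

In this assay, replacing the aromatic group at this amide-type nitrogen gives an at least 10-fold higher number from compound 3 to compound 4 (1.00 log units; beyond the scatter), and the comparison with the other aromatic compound gives an at least 10-fold higher number from compound 1 to compound 4 (1.02 log units; beyond the scatter). Until now, only acetyl had produced such a rise, so the change is not confined to that group: 3-(methylsulfanyl)propyl has no ring and no carbonyl, yet gives a limit as well. For compound 2 and compound 4, the step between them cannot be read, as both values are limits and not numbers: the limit of > 100000 nM in this assay, at which 2 of the 4 values shown sit.

From the compounds shown here alone, whether the rise follows the loss of the aromatic ring or the presence of the sulfur in the chain stays open. Cyclohexyl or a plain butyl chain at this nitrogen would separate the two.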